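Chloro for fluoro on compound 3

A few compounds are considered here, and "the series" means these few. Any claim that something is new, unique, unknown or untested is made for them only; others in the source may bear on it.

In a functional assay on THP-1 cells (Homo sapiens) for cytotoxicity, read by MTT assay, with a stated time of 24 h (a higher number here means a weaker inhibitor, a lower number a stronger inhibitor), compound 3 (`COc1cc(/C=C2\CN(C)C/C(=C\c3ccc(F)cc3)C2=O)cc(OC)c1OC`) gives 6130 nM and lies within the scatter of compound 2 (`COc1cc(/C=C2\CN(C)C/C(=C\c3ccc(Cl)cc3)C2=O)cc(OC)c1`) with 5860 nM and well above compound 1 (`COc1cc(/C=C2\CN(C)C/C(=C\c3ccccc3F)C2=O)cc(OC)c1OC`) with 640 nM on this scale. Compound 4 (`COc1cc(/C=C2\CN(C)C/C(=C\c3ccc(Cl)cc3)C2=O)cc(OC)c1OC`) has chloro in place of fluoro on an aromatic carbon. Among the compounds with values here, the one measured step (a 9.6-fold higher number from compound 1 to compound 3 (0.98 log units; beyond the scatter)) moves the fluoro group and keeps the same halogen, so it bears only indirectly on this swap. Compound 2 carries the same 4-chlorophenyl group but differs elsewhere, and its 5860 nM gives no sign of a large shift. The expected change is only a 1.1-fold lower number from compound 3 to compound 4 (0.05 log units; within the scatter) and so stays within the scatter. The estimated value for compound 4 is 5500 nM (range 2300 nM to 13000 nM).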

Compound 4, half-maximal inhibitory concentration: 7200 nM
Compound 4: middle estimate off by 1.3-fold (0.12 log units), on the low side; the measured number falls inside the stated range.
By their numbers in this assay, from the lowest: compound 1; then compounds 2, 3 and 4 (each within the scatter of the next).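

In this assay chloro in place of fluoro on this aromatic carbon gives a 1.2-fold higher number from compound 3 to compound 4 (0.07 log units; within the scatter) and stays within the scatter, so the assay does not separate these two halogens here. Methoxy in place of hydrogen on an aromatic carbon gives a 1.2-fold higher number from compound 2 to compound 4 (0.09 log units; within the scatter) and also stays within the scatter. Of these steps only 4-chlorophenyl in place of 2-fluorophenyl, with an 11-fold higher number from compound 1 to compound 4 (1.05 log units; beyond the scatter) as its size, lies beyond the scatter. On these data alone, whether an amine or a nitrile on that same aromatic carbon would give a number in line with the two halogens stays open. No measurement at hand explains any of these results.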